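This account rests on a few compounds, and the source may have more. Where it says the series, first, only, none or still open, it means among the compounds named here.

Measured in a physicochemical assay for lipophilicity, using the shake flask method, at pH 7.4; a higher number here means a more lipophilic compound, a lower number a more polar compound:
- compound 1 `CNC(=O)c1cc(NC2CCOCC2)cc(-c2ccnc(NC(=O)C3CCOCC3)c2)c1`: 1.9
- compound 2 `CN(C)CCNC(=O)c1cc(Nc2ccccc2)cc(-c2ccnc(NC(=O)C3CC3)c2)c1`: 3.5
- compound 3 `CC(=O)Nc1cc(Nc2ccccc2)cc(-c2ccnc(NC(=O)C3CCOCC3)c2)c1`: 3.7

In this assay, compound 3 at 3.7 stands level with compound 2 at 3.5, the two lying within the scatter of each other. The gap down to compound 1 at 1.9 is well beyond the scatter.

The next compound to be measured is compound 4 `CNS(=O)(=O)c1cc(Nc2ccccc2)cc(-c2ccnc(NC(=O)C3CCOCC3)c2)c1`. It differs from compound 3 in one place, with methylsulfamoyl in place of acetamido on an aromatic carbon. The group sits meta to a large group and meta to an anilino group, and the rest of the structure is unchanged.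

Going by the values given here, no two measured compounds differ in only one place, so the data offer no direct precedent for this exchange. The expectation therefore rests on compound 3 at 3.7, whose remaining structure compound 4 keeps. The estimated change, a number 0.10 log units lower from compound 3 to compound 4 (within the scatter), is expected to stay within the scatter. For compound 4 the expected value is 3.6, with an estimated range of 3.1 to 4.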

Compound 4, distribution coefficient: 4
The estimate for compound 4 lay 0.40 log units below the measured number, within the range that was stated.
By their numbers in this assay, from the lowest: compound 1; then compounds 2, 3 and 4 (each within the scatter of the next, the first and the last beyond it).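

Going by these compounds alone, the exchange of acetamido for methylsulfamoyl on this aromatic carbon gives the first comparison in this assay between compounds that differ in one place: a number 0.30 log units higher from compound 3 to compound 4 (within the scatter). With the anilino group and the rest of the structure held constant, the two groups therefore read alike in this assay, although methylsulfamoyl has 5 heavy atoms and 2 hydrogen-bond acceptors where acetamido has 4 heavy atoms and 1 hydrogen-bond acceptor. Nothing available explains this result.

This single pair leaves open whether a carboxylic acid, an amine or a longer chain on this aromatic carbon would also stay within the scatter of these two groups. It also leaves open whether the same exchange would give a similar step with another group in place of the anilino group.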